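The compounds below may be only part of what the source reports. "The series", "measured", "known", "first", "only" and "open" are said of these compounds alone.

Compound 1, with the structure `CCc1ccccc1NC(=O)N[C@@H](C)c1ccccc1`, was examined in an ADME assay on the whole organism with Oryza sativa as the target, tested at 0.1 uM (a higher number here means a weaker effect of the compound at the concentration tested, a lower number a stronger effect), where compound 1 gives 100%. Compound 3, with the structure `CC(C)c1ccccc1NC(=O)N[C@@H](C)c1ccccc1`, differs from compound 1 by methyl in place of hydrogen on a saturated chain carbon bound to an aromatic carbon and a saturated chain carbon. In this assay compound 3 gives 99%, and the step is a number 1 percentage points lower from compound 1 to compound 3 (within the scatter). Compound 2, with the structure `CCc1cccc(NC(=O)N[C@H](C)c2ccccc2)c1`, is built on a core whose difference from the core of compound 1 is not broken down here. In this assay compound 2 gives 97%. The three values of compound 1, compound 2 and compound 3 lie within the usual scatter of one another, so no order among them can be read from these numbers.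

Compound 4, with the structure `CC(C)c1cccc(NC(=O)N[C@H](C)c2ccccc2)c1`, has not yet been measured in this assay. It differs from compound 2 by methyl in place of hydrogen on a saturated chain carbon bound to an aromatic carbon and a saturated chain carbon. This is the same change that leads from compound 1 to compound 3, made on the core of compound 2 instead. Because that earlier step was a number 1 percentage points lower from compound 1 to compound 3 (within the scatter), the step from compound 2 to compound 4 is expected to be of similar size, a number 1 percentage points lower from compound 2 to compound 4 (within the scatter). This rests on a single pair, compound 1 and compound 3, so the expectation carries the uncertainty of one observation. Compound 4 is therefore estimated to give 96% in this assay, within a range from 87% to 100%.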

Compound 4, a percentage reported as activity, at one concentration (the size of the read-out at that concentration, not a potency): 74%
Estimate against measurement, compound 4: 22 percentage points above; measured number outside the range, below it.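

In this assay the change from ethyl to isopropyl comes out as a number 23 percentage points lower from compound 2 to compound 4 (beyond the scatter) and is therefore a real step on this core, whereas it could not be told from the scatter on the core of compound 1. The size of this change thus does not carry over from one core to the other, so a step read on one of these cores is a poor guide to the same step on the other: the same change on two cores in this assay, a number 1 percentage points lower (within the scatter) from compound 1 to compound 3 and a number 23 percentage points lower (beyond the scatter) from compound 2 to compound 4, 22 percentage points apart, beyond the scatter of two such steps. This shows that the outcome of the change depends on the core it is made on, but it rests on two pairs alone, and it does not show which difference between the two cores matters, why the steps part, or that isopropyl lowers the number in general, since compound 3 and compound 1 go against such a rule.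

The compounds shown leave open whether a longer chain such as n-propyl, or a bulkier group such as tert-butyl or cyclopropyl, in place of the ethyl would continue the step seen on the core of compound 2 or stay within the scatter on the core of compound 1. They also leave open how the same change would behave on any third core.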